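The compounds below may be only part of what the source reports. "The series", "measured", "known", "first", "only" and "open" are said of these compounds alone.

Measured compounds in an assay on HEK293 cells for displacement of a labelled ligand from Melanocortin receptor 4 (Homo sapiens); on this read-out higher numbers stand for weaker inhibition and lower numbers for stronger inhibition:
compound 1 `CCC(=O)N1C[C@@H](C(=O)N2CCN(c3ccc(C)cc3[C@@H](NC(=O)CCN(C)C)C(C)C)CC2)[C@H](c2ccc(Cl)cc2)C1` at 4.6 nM
compound 2 `CNCC(=O)N[C@H](c1cc(C)ccc1N1CCN(C(=O)[C@@H]2CN(C3CCOCC3)C[C@H]2c2ccc(Cl)cc2)CC1)C(C)C` at 2.1 nM
compound 3 `CC(C)[C@H](NC(=O)CCN(C)C)c1cccc(F)c1N1CCN(C(=O)[C@@H]2CN(C(C)C)C[C@H]2c2ccc(C(F)(F)F)cc2F)CC1` at 61 nM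

Among these three, compound 2 shows the lowest number in this assay, with compound 1 the nearest and compound 3 the furthest, both gaps lying beyond the scatter. Compound 4 `Cc1ccc(N2CCN(C(=O)[C@@H]3CN(C4CCOCC4)C[C@H]3c3ccc(Cl)cc3)CC2)c([C@@H](NC(=O)CCN)C(C)C)c1` has not yet been measured. It keeps every atom of compound 2 but joins them differently: aminomethyl in place of methylamino on a saturated chain carbon bound to a carbonyl carbon. Within the data shown here, no measured pair shows this exact change. Since the two chains carry the same counted features, only a small shift in this assay is expected, if any beyond the scatter, with a modest loss considered slightly more likely than a gain. The step from compound 2 to compound 4 is therefore estimated at a 1.7-fold higher number from compound 2 to compound 4 (0.22 log units; within the scatter). Compound 4 is expected to give about 3.5 nM, within a range of 1.2 nM to 10 nM.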

Compound 4, inhibition constant: 2.2 nM
Estimate against measurement, compound 4: 1.6-fold (0.20 log units) above; low and high end bracket the measured number.
By their numbers in this assay, from the lowest: compounds 2 and 4 (each within the scatter of the next); then compound 1; then compound 3.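

In this assay, aminomethyl in place of methylamino on a saturated chain carbon bound to a carbonyl carbon gives a 1.0-fold higher number from compound 2 to compound 4 (0.02 log units; within the scatter). The earlier compounds shown here offered no pair differing in one place, and this pair now shows that, at this place, the two arrangements of the same atoms cannot be told apart on this read-out. Nothing available bears on the reason for this result.

From the compounds shown here alone, whether a longer chain such as 3-aminopropyl would read the same here remains open. So does the effect of a carboxylic acid at this place.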